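Series notes: chloro in place of methoxy, compound 3

This account rests on a few compounds, and the source may have more. Where it says the series, first, only, none or still open, it means among the compounds named here.

Compound 1 `COc1ccc(Nc2nc3ccccc3nc2S(=O)(=O)c2ccccc2)cc1` gives 1510 nM in a functional assay on PC-3 cells (Homo sapiens) for cytotoxicity, read by MTT assay, with a stated time of 72 h; on this read-out lower numbers stand for stronger inhibition and higher numbers for weaker inhibition. Compound 2 `COc1ccc(Nc2nc3ccccc3nc2S(=O)(=O)c2ccc(C)cc2)cc1` sits at the limit (the limit of > 50000 nM in this assay, at which 1 of the 2 values shown sits). In this assay compound 2 gives > 50000 nM, a limit and not a number. Among the compounds with values here, the one measured step, an at least 33-fold higher number from compound 1 to compound 2 (1.51 log units; beyond the scatter), concerns methyl in place of hydrogen on an aromatic carbon and does not cover the change now in question. Compound 3 `Cc1ccc(S(=O)(=O)c2nc3ccccc3nc2Nc2ccc(Cl)cc2)cc1` differs from compound 2 by chloro in place of methoxy on an aromatic carbon. Within the data shown here, no measured step covers chloro in place of methoxy, so the data give no direction for this change. Compound 3 is expected to stay near the limit, the estimated step being a number no higher from compound 2 to compound 3 (the limit leaves the size open). The estimate for compound 3 in this assay is 50000 nM, with a range from 15000 nM to 150000 nM.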

Compound 3, half-maximal inhibitory concentration: 9660 nM
Estimate against measurement, compound 3: 5.2-fold (0.71 log units) above; measured number outside the range, below it.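

In this assay, within the data shown here, the change from (4-methoxyphenyl)amino to (4-chlorophenyl)amino gives an at least 5.1-fold lower number from compound 2 to compound 3 (0.71 log units; beyond the scatter) and is the first measured step at this position. With the methyl kept, this position can therefore move the read-out off the limit. The step has no upper bound, because compound 2 carries a limit and not a number: the limit of > 50000 nM in this assay, at which 1 of the 3 values shown sits.

As far as these compounds go, whether chloro in place of methoxy gives a similar step without the methyl stays open. So does the effect on the read-out of an amine or a carboxylic acid at this position.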